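The compounds below may be only part of what the source reports. "The series", "measured", "known", "first", "only" and "open" are said of these compounds alone.

Three compounds sharing one core have been measured in a functional assay on HCT-116 cells (Homo sapiens) for cytotoxicity, read by sulforhodamine B assay, with a stated time of 24 h; a lower number here means a stronger inhibitor, a higher number a weaker inhibitor:

Compound 1 `N/N=C1\C(=O)Nc2ccc(S(=O)(=O)N3CCOCC3)cc21`: 36300 nM
Compound 2 `O=C1Nc2ccc(S(=O)(=O)N3CCOCC3)cc2/C1=N/NS(=O)(=O)c1ccccc1`: 13300 nM
Compound 3 `O=C1Nc2ccc(S(=O)(=O)N3CCOCC3)cc2/C1=N/c1ccc(C(=O)O)cc1`: 23600 nM

Compound 3 holds the second highest of these three numbers, but neither neighbour is clearly apart from it: the step of a 1.5-fold lower number from compound 1 to compound 3 (0.19 log units; within the scatter) and the step of a 1.8-fold higher number from compound 2 to compound 3 (0.25 log units; within the scatter) both fall within the scatter of repeated measurements. Within the data shown here, the only step beyond the scatter is a 2.7-fold lower number from compound 1 to compound 2 (0.44 log units; beyond the scatter), a modest change.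

Compound 4 `CC(=O)c1cccc(/N=C2\C(=O)Nc3ccc(S(=O)(=O)N4CCOCC4)cc32)c1` has not yet been measured. It differs from compound 3 at the double-bonded nitrogen: 3-acetylphenyl in place of 4-carboxyphenyl on a double-bonded nitrogen. Among the measured compounds shown here, the steps that bear on this change are those that also alter the group on that double-bonded nitrogen, namely the step from compound 1 to compound 3 and the step from compound 2 to compound 3, and both were small. With no measured exchange of one aryl group for another at that position, the data give little reason to expect a shift beyond the scatter in either direction.

Compound 4 is therefore estimated at 20000 nM, with a range from 8000 nM to 50000 nM, which means an expected step of a 1.2-fold lower number from compound 3 to compound 4 (0.07 log units; within the scatter).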

Compound 4, half-maximal inhibitory concentration: 29000 nM
For compound 4 the middle estimate is 1.5-fold (0.16 log units) below the measured one; measured number inside the range.
By their numbers in this assay, from the lowest: compounds 2, 3, 4 and 1 (each within the scatter of the next, the first and the last beyond it).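

Among these compounds, compound 4 provides the first exchange of one aryl group for another on the double-bonded nitrogen, and in this assay this step stays within the scatter (a 1.2-fold higher number from compound 3 to compound 4 (0.09 log units; within the scatter)), even though 3-acetylphenyl has no hydrogen-bond donor and 4-carboxyphenyl has one. The comparison with the other two groups at this position divides the same way as before: the step from (phenylsulfonyl)amino is modest but beyond the scatter (a 2.2-fold higher number from compound 2 to compound 4 (0.34 log units; beyond the scatter)), while the step from amino stays within it (a 1.3-fold lower number from compound 1 to compound 4 (0.10 log units; within the scatter)), so 3-acetylphenyl sits apart from (phenylsulfonyl)amino but not from amino or 4-carboxyphenyl. Nothing available explains these numbers.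

The exchange from compound 3 to compound 4 alters both the group and the place where it sits on the phenyl ring, so the compounds shown cannot separate these two changes, and a 3-carboxyphenyl or 4-acetylphenyl group would be needed to do so. As far as these compounds go, it also remains open whether a plain phenyl group, or a phenyl group carrying an amine, would move the number beyond the scatter from compound 3.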